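Two Methyls on the Saturated Ring Carbon of Compound 2

The source may hold more compounds than are shown below. What is called first, only, known or untested is meant among the compounds shown, and "the series" means these compounds.

Compound 2 `COc1cc2c(cc1N1CCNCC1)N(S(=O)(=O)c1ccc(-c3ccccn3)s1)CC2` is the lower of the two compounds measured in a functional assay with growth hormone secretagogue receptor type 1 (Homo sapiens) as the target (on this read-out lower numbers stand for smaller maximal responses and higher numbers for larger maximal responses), where compound 2 gives 0.8. Compound 1 `COc1cc2c(cc1N1CCN[C@@H](C)C1)N(S(=O)(=O)c1ccc(-c3ccccn3)s1)CC2` gives 1 in this assay. Compound 3 `COc1cc2c(cc1N1CCNC(C)(C)C1)N(S(=O)(=O)c1ccc(-c3ccccn3)s1)CC2` differs from compound 2 by 3,3-dimethylpiperazin-1-yl in place of piperazin-1-yl on an aromatic carbon. For the measured compounds named here, the one known step, a number 0.20 lower from compound 1 to compound 2 (beyond the scatter), bears on this change. Because a number 0.20 lower from compound 1 to compound 2 (beyond the scatter) went with hydrogen in place of methyl on a saturated ring carbon, putting two methyls on that carbon is expected to raise the response, by a number 0.15 higher from compound 2 to compound 3 (beyond the scatter). Compound 3 is therefore estimated at 0.95, with a range from 0.75 to 1.1.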

Compound 3, intrinsic activity: the largest response reached, as a fraction of the reference agonist's: 0.9
Compound 3: the middle estimate sits 0.050 above what was measured; the measured number falls inside the stated range.
By their numbers in this assay, from the lowest: compounds 2, 3 and 1 (each within the scatter of the next, the first and the last beyond it).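

In this assay, the 3,3-dimethylpiperazin-1-yl group of compound 3 cannot be separated from either neighbour: piperazin-1-yl (a number 0.10 higher from compound 2 to compound 3 (within the scatter)) or 3-methylpiperazin-1-yl (a number 0.10 lower from compound 1 to compound 3 (within the scatter)). Adding the second methyl therefore gives no response distinct from that with one methyl, and only compound 1 and compound 2 stand apart beyond the scatter. Nothing available here accounts for this result.

As far as these compounds go, whether an ethyl group or a fluorine on that saturated ring carbon would give a different response remains open.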